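This account rests on a few compounds, and the source may have more. Where it says the series, first, only, none or still open, it means among the compounds named here.

The cytotoxicity of a small set of compounds toward monkey kidney cells was examined in an ADME assay on Vero cells (Chlorocebus sabaeus) for cytotoxicity, read by MTT assay, with a stated time of 72 h; on this read-out higher numbers stand for weaker inhibition and lower numbers for stronger inhibition. Compound 1 `O=C(c1ccncc1)N1N=C(c2cc3ccccc3o2)CC1c1ccc(Cl)cc1` carries a 4-chlorophenyl group on the saturated ring of its core. In this assay compound 1 gives > 220000 nM, which is a limit of the assay rather than a number, as recorded in the limit of > 220000 nM in this assay, at which 1 of the 3 values shown sits. Compound 2 `O=C(c1ccncc1)N1N=C(c2cc3ccccc3o2)CC1c1ccccc1Cl` differs from compound 1 by 2-chlorophenyl in place of 4-chlorophenyl on a saturated ring carbon. In this assay compound 2 gives > 210000 nM, again a limit of the assay, recorded in the limit of > 210000 nM in this assay, at which 1 of the 3 values shown sits. The step that the two limits leave unreadable from compound 1 to compound 2 therefore yields no usable size. Compound 3 `CCn1cc(C(=O)N2N=C(c3cc4ccccc4o3)CC2c2ccc(Cl)cc2)c(=O)c2ccc(C)nc21` has a different core; the difference between the two cores is not broken down here. In this assay compound 3 gives > 160000 nM, which is a limit of the assay, recorded in the limit of > 160000 nM in this assay, at which 1 of the 3 values shown sits. Compound 4 `CCn1cc(C(=O)N2N=C(c3cc4ccccc4o3)CC2c2ccccc2Cl)c(=O)c2ccc(C)nc21`, not yet measured, differs from compound 3 by 2-chlorophenyl in place of 4-chlorophenyl on a saturated ring carbon. Among the compounds with values here, this is the same kind of change as the one from compound 1 to compound 2, though the surroundings differ: in compound 1 the changed carbon sits next to the ring atom that bears a (pyridin-4-yl)carbonyl group, while in compound 3 it sits next to the ring atom that bears a large group. Because a step that the two limits leave unreadable from compound 1 to compound 2 rests on limits at both ends, no size can be attached to this change, and the step from compound 3 to compound 4 is expected to be negligible, a step that the limit leaves unreadable from compound 3 to compound 4. Compound 4 is expected to give roughly 200000 nM in this assay, most likely reported only as a limit, somewhere between 100000 nM and 400000 nM.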

Compound 4, half-maximal inhibitory concentration: > 178000 nM
Compound 4: a limit, no number (the forecaster's own chance of this, stated with the estimate: 85%); the middle value lies beyond the limit too.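

Compound 3 and compound 4 are both recorded only as limits of the assay, not as numbers, so no size can be read for putting 2-chlorophenyl in place of 4-chlorophenyl between them. The compounds shown leave open whether this change shifts the result in this assay at all, and at what concentration, if any, any of the four compounds would reach half-maximal inhibition.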